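The compounds below may be only part of what the source reports. "The series", "measured", "known", "first", "only" and "open" are said of these compounds alone.

Series notes. For the measured compounds named here, compound 1 `O=C(CN1CCN(c2ccccn2)CC1)Nc1cccnc1` gives 1080 nM in a functional assay on cells for agonist activity at D(4) dopamine receptor (Homo sapiens), read by TR-FRET and cAMP accumulation, with a stated time of 30 min; on this read-out higher numbers stand for an effect only at larger amounts of compound and lower numbers for an effect already at smaller amounts; compound 2 `CCc1cccc(NC(=O)CN2CCN(c3ccccn3)CC2)c1` gives 28.7 nM, and the change a 38-fold lower number from compound 1 to compound 2 (1.58 log units; beyond the scatter) is the one measured step. Compound 3 `Cc1cccc(NC(=O)CN2CCN(c3ncccn3)CC2)c1` gives 3.4 nM, the lowest number of the three, and both other compounds lie beyond the scatter from it.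

Compound 4 `Cc1cccc(NC(=O)CN2CCN(c3ccccn3)CC2)c1` differs from compound 3 by pyridin-2-yl in place of pyrimidin-2-yl on an amine nitrogen in a ring. Going by the values given here, no measured step touches this ring; the step from compound 1 to compound 2 concerns the amide side only. Compound 2 carries the same pyridin-2-yl group and gives a higher number than compound 3, so a modest rise is expected: compound 4 is estimated at 8 nM (range 2.5 nM to 30 nM), a step of a 2.4-fold higher number from compound 3 to compound 4 (0.37 log units; beyond the scatter) expected, though it may well stay within the scatter.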

Compound 4, half-maximal effective concentration: 3.6 nM
Estimate against measurement, compound 4: 2.2-fold (0.35 log units) above, within the range that was stated.
By their numbers in this assay, from the lowest: compounds 3 and 4 (each within the scatter of the next); then compound 2; then compound 1.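

With 3-methylphenyl on the amide-type nitrogen, pyridin-2-yl and pyrimidin-2-yl on the amine nitrogen in a ring cannot be told apart in this assay (a 1.1-fold higher number from compound 3 to compound 4 (0.02 log units; within the scatter)), so this pair gives no read-out for the second ring nitrogen. Steps beyond the scatter here lie on the amide side: hydrogen in place of methyl on the chain (an 8.0-fold lower number from compound 2 to compound 4 (0.90 log units; beyond the scatter)), and 3-methylphenyl in place of pyridin-3-yl (a 300-fold lower number from compound 1 to compound 4 (2.48 log units; beyond the scatter)). No available measurement explains these steps. As far as these compounds go, whether a quinolin-2-yl group, or a pyridin-2-yl ring carrying chlorine or methoxy, fits this position remains open.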